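Changing the Sulfonamide Substituent: Oral Bioavailability Outlook

A few compounds are considered here, and "the series" means these few. Any claim that something is new, unique, unknown or untested is made for them only; others in the source may bear on it.

Three measured compounds share one core and differ only in the group on the sulfonamide nitrogen. Compound 1 `O=S(=O)(Nc1ccc(O)cc1)c1ccc2nc(-c3ccccc3)c(-c3ccccc3)nc2c1` carries a 4-hydroxyphenyl there, compound 2 `O=S(=O)(Nc1cccc2ccccc12)c1ccc2nc(-c3ccccc3)c(-c3ccccc3)nc2c1` a naphthalen-1-yl, and compound 3 `O=S(=O)(Nc1ccc2ccccc2c1)c1ccc2nc(-c3ccccc3)c(-c3ccccc3)nc2c1` a naphthalen-2-yl. In an ADME assay on the whole organism for pharmacokinetics, with Homo sapiens as the target (a higher number here means that a larger share of the oral dose reaches the circulation, a lower number that a smaller share of the oral dose reaches the circulation), compound 1 gives 93.9%, compound 2 gives 100% and compound 3 gives 100%. Compound 3 thus stands level with compound 2 at the digits shown, the two together the highest of the three, and the step of a number 6.1 percentage points higher from compound 1 to compound 3 (within the scatter) remains within the scatter. The step of no change at the digits printed from compound 2 to compound 3 (within the scatter) is likewise within the scatter.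

Compound 4 `O=[N+]([O-])c1cccc(NS(=O)(=O)c2ccc3nc(-c4ccccc4)c(-c4ccccc4)nc3c2)c1` carries the change (3-nitrophenyl in place of naphthalen-2-yl on a sulfonamide nitrogen). For the measured compounds named here, no measured pair contains a 3-nitrophenyl, so the only guide is that every exchange made so far on the sulfonamide nitrogen, including a number 6.1 percentage points higher from compound 1 to compound 2 (within the scatter) and the two steps above, stayed within the scatter. A shift beyond the scatter in this assay is therefore not expected. The estimated step is a number 8 percentage points lower from compound 3 to compound 4 (within the scatter). For compound 4 the expected value in this assay is 92%, with a range from 72% to 100%.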

Compound 4, oral bioavailability: 85.6%
Compound 4: the middle estimate sits 6.4 percentage points above what was measured, within the range that was stated.
By their numbers in this assay, from the lowest: compounds 4, 1, 2 and 3 (each within the scatter of the next, the first and the last beyond it).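

For the compounds shown here, the sulfonamide nitrogen can no longer be described as a place where every exchange stays within the scatter: in this assay, putting 3-nitrophenyl there gives a number 14.4 percentage points lower from compound 3 to compound 4 (beyond the scatter) and a number 14.4 percentage points lower from compound 2 to compound 4 (beyond the scatter), the first steps at this position to pass beyond it. The same group set against the 4-hydroxyphenyl gives a number 8.3 percentage points lower from compound 1 to compound 4 (within the scatter), so compound 4 is separated from the two compounds carrying a naphthalene group but not from compound 1, which lies within the scatter of all the others. No measurement at hand bears on why oral exposure moves with this exchange.

The exchange from naphthalen-2-yl to 3-nitrophenyl removes one aromatic ring and brings in a nitro group at the same time, and the compounds shown do not separate these two parts of the change. Also open, as far as these compounds go, is how a plain phenyl group on the sulfonamide nitrogen would read in this assay, and how a phenyl ring carrying an amine or a carboxylic acid in place of the nitro group would read there.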